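The compounds below may be only part of what the source reports. "The series", "measured", "known", "first", "only" and "open" are said of these compounds alone.

Series of ureas on a shared core: compound 1 `Cc1cc(NC(=O)Nc2ccccc2C(F)(F)F)c2ccccc2n1`, compound 2 `Cc1cc(NC(=O)Nc2ccc(O)cc2)c2ccccc2n1`, compound 3 `Cc1cc(NC(=O)Nc2cccc(C(F)(F)F)c2)c2ccccc2n1` and the not yet measured compound 4 `Cc1cc(NC(=O)Nc2ccccc2C(N)=O)c2ccccc2n1`. In an ADME assay on HepG2 cells (Homo sapiens) for cytotoxicity, with a stated time of 72 h (a higher number here means that more compound is needed for the effect, a lower number that less compound is needed), compound 1 gives > 25000 nM, which is a limit of the assay and not a number. Compound 2 likewise gives > 25000 nM in this assay, again a limit. Compound 3 gives 21000 nM in this assay. Within the data shown here, compound 1 thus stands at the limit of > 25000 nM in this assay, at which 2 of the 3 values shown sit; no pair of measured compounds differs in one place, so no measured step is available as a guide. The change from compound 1 to compound 4 is carbamoyl in place of trifluoromethyl on an aromatic carbon. With the measured values all sitting at or close to the limit, the expectation in this assay is no step beyond the scatter. Compound 4 is therefore estimated at 25000 nM in this assay, expected to fall between 15000 nM and 60000 nM, and most likely to be reported as a limit only. The expected step is a number no higher from compound 1 to compound 4 (the limit leaves the size open), none beyond the scatter.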

Compound 4, half-maximal effective concentration: > 25000 nM
Compound 4: only a limit was reported (the forecaster's own chance of this, stated with the estimate: 70%); the middle value lies on the limit itself.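

Compound 1 and compound 4 both give only a limit in this assay, so no step can be read between them: the limit of > 25000 nM in this assay, at which 3 of the 4 values shown sit.

The compounds shown leave open what carbamoyl in place of trifluoromethyl on an aromatic carbon does to the concentration needed for the effect.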